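Styryl in place of methoxyphenyl on a sulfonamide benzoic acid

The source may hold more compounds than are shown below. What is called first, only, known or untested is meant among the compounds shown, and "the series" means these compounds.

Measured compounds:
compound 1 `CCCCCCCCS(=O)(=O)Nc1cc(-c2ccccc2O)ccc1C(=O)O`: 63100 nM
compound 2 `CCCCCCCCS(=O)(=O)Nc1ccc(-c2ccc(-c3ccccc3)cc2)cc1C(=O)O`: 29100 nM
compound 3 `CCCCCCCCS(=O)(=O)Nc1ccc(-c2ccc(OC)cc2)cc1C(=O)O`: 19500 nM

Three compounds share a core carrying an octylsulfonamide and a carboxylic acid, and all were tested in an assay on mitochondria (strain BALB/c) for inhibition of glycerol-3-phosphate acyltransferase 1, mitochondrial (Mus musculus), read by scintillation counting, with a stated time of 10 min; on this read-out higher numbers stand for weaker inhibition and lower numbers for stronger inhibition. Compound 1 gives 63100 nM, compound 2 gives 29100 nM and compound 3 gives 19500 nM. Compound 3 therefore shows the lowest number of the three; its gap to compound 2 is within the scatter, while its gap to compound 1 lies beyond it.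

For the measured compounds named here, the single measured step, a 1.5-fold lower number from compound 2 to compound 3 (0.17 log units; within the scatter), exchanges one group on the same aromatic carbon and changes little. Compound 4 `CCCCCCCCS(=O)(=O)Nc1ccc(/C=C/c2ccccc2)cc1C(=O)O` differs from compound 3 by 2-phenylethenyl in place of 4-methoxyphenyl on an aromatic carbon. Going by the values given here, no measured step involves a 2-phenylethenyl group, so the only guide is that replacing one eight-atom group by another at this position, as in the step from compound 2 to compound 3, stayed within the scatter. Compound 4 is therefore expected to give about 22000 nM in this assay, between 8000 nM and 60000 nM, a step of a 1.1-fold higher number from compound 3 to compound 4 (0.05 log units; within the scatter) that is estimated to remain within the scatter.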

Compound 4, half-maximal inhibitory concentration: 16300 nM
Estimate against measurement, compound 4: 1.3-fold (0.13 log units) above, and the stated range covers the measured number.
By their numbers in this assay, from the lowest: compounds 4, 3 and 2 (each within the scatter of the next); then compound 1.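

The step of a 1.2-fold lower number from compound 3 to compound 4 (0.08 log units; within the scatter) shows that this position tolerates more than a change of ring substituent: 4-methoxyphenyl gives way to 2-phenylethenyl, which has no hydrogen-bond acceptor and brings a double bond outside the aromatic ring, yet the two compounds cannot be told apart in this read-out. Together with the earlier step of a 1.5-fold lower number from compound 2 to compound 3 (0.17 log units; within the scatter), it means that neither exchange of one large carbon-rich group for another at this position has moved the number beyond the scatter. Nothing shown gives a reason for this flat response.

From the compounds shown here alone, whether an amine or a second carboxylic acid at this position, or a shorter chain in place of the octyl chain, would shift the number beyond the scatter remains open. For the compounds shown here, compound 1 differs from the others in more than one place, and no step connects it to them.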